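Aryl swap on the thiourea arm of a shared core

The source may hold more compounds than are shown below. What is called first, only, known or untested is meant among the compounds shown, and "the series" means these compounds.

Within the data shown here, compound 2 `CSc1ccccc1NC(=S)N1CCc2c(sc(NC(=O)c3ccccc3Cl)c2C(N)=O)C1` gives 14600 nM in a functional assay on HL-60 cells (Homo sapiens) for antiproliferative activity, with a stated time of 24 h (a lower number here means a stronger inhibitor, a higher number a weaker inhibitor), the highest of the two numbers so far, though its nearest neighbour, compound 1 `NC(=O)c1c(NC(=O)c2ccccc2Cl)sc2c1CCN(C(=S)Nc1cccc3ccccc13)C2`, gives 13400 nM in this assay, which lies within the scatter. Among the measured compounds shown here, the one measured step, a 1.1-fold higher number from compound 1 to compound 2 (0.04 log units; within the scatter), thus shows that exchanging one aryl group for another on the thiourea nitrogen left the number essentially unchanged. Compound 3 `NC(=O)c1c(NC(=O)c2ccccc2Cl)sc2c1CCN(C(=S)Nc1ccc(C(F)(F)F)cc1)C2` differs from compound 2 by 4-(trifluoromethyl)phenyl in place of 2-(methylsulfanyl)phenyl on an amide-type nitrogen. For the measured compounds named here, this is again an exchange of one aryl group on the same amide-type nitrogen, so the step from compound 1 to compound 2 is the only measured step that bears on it, and it was within the scatter. No other evidence is available, and nothing suggests the outcome should differ. Compound 3 is therefore expected to show a step of a 1.0-fold lower number from compound 2 to compound 3 (0.02 log units; within the scatter), that is, no change beyond the scatter. Compound 3 is estimated at 14000 nM, with a range from 5000 nM to 40000 nM.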

Compound 3, half-maximal inhibitory concentration: 7590 nM
Compound 3: middle estimate off by 1.8-fold (0.27 log units), on the high side, within the range that was stated.
By their numbers in this assay, from the lowest: compounds 3, 1 and 2 (each within the scatter of the next).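

In this assay, moving to 4-(trifluoromethyl)phenyl on the amide-type nitrogen gives a 1.9-fold lower number from compound 2 to compound 3 (0.28 log units; within the scatter) and a 1.8-fold lower number from compound 1 to compound 3 (0.25 log units; within the scatter), so this third aryl group also stays within the scatter of both earlier ones. The earlier compounds showed only that naphthalen-1-yl and 2-(methylsulfanyl)phenyl could not be told apart, whereas the three compounds now show that the number holds within the scatter across a fused aromatic system, a sulfur-bearing phenyl and a fluorine-bearing phenyl, so that no order can be drawn among these groups at this position. No measurement is available that could explain this result.

As far as these compounds go, all three groups attach through an aromatic ring, so it remains open whether a butyl chain, or a phenyl ring carrying an amine or a carboxylic acid, would move the number in this assay beyond the scatter. The rest of the shared core is identical in all three compounds, which leaves open how the number would respond to a change anywhere else in the structure.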